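Chloro to trifluoromethyl on the pendant aryl ring

The compounds below may be only part of what the source reports. "The series", "measured", "known", "first", "only" and "open" are said of these compounds alone.

Three compounds of this series have numbers in a functional assay on PC-3 cells (Homo sapiens) for cytotoxicity, read by MTT assay, with a stated time of 72 h; on this read-out lower numbers stand for stronger inhibition and higher numbers for weaker inhibition. Compound 1 `O=C(Nc1ccc(Oc2ccnc3[nH]ccc23)cc1)c1cc(-c2ccc(C(F)(F)F)cc2)ncn1` gives 2160 nM. Compound 2 `COc1ccc(-c2cc(C(=O)Nc3ccc(Oc4ccnc5[nH]ccc45)c(F)c3)ncn2)cc1` gives 2570 nM. Compound 3 `O=C(Nc1ccc(Oc2ccnc3[nH]ccc23)c(F)c1)c1cc(-c2ccc(Cl)cc2)ncn1` gives 3200 nM, the highest of the three numbers, but its nearest neighbour is compound 2 and the gap is a 1.2-fold higher number from compound 2 to compound 3 (0.10 log units; within the scatter), while the gap to compound 1 is also within the scatter, so no order among the three can be read.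

Compound 4 `O=C(Nc1ccc(Oc2ccnc3[nH]ccc23)c(F)c1)c1cc(-c2ccc(C(F)(F)F)cc2)ncn1` is not yet measured. It differs from compound 3 by trifluoromethyl in place of chloro on an aromatic carbon. Within the data shown here, no measured pair carries this exact change. Among the measured compounds shown here, the one measured step, from compound 2 to compound 3, swaps methoxy for chloro at the same position and came out as a 1.2-fold higher number from compound 2 to compound 3 (0.10 log units; within the scatter), within the scatter. Compound 1 carries the trifluoromethyl group but lacks the fluoro substituent of compound 3, so only its value can be set beside that of compound 3, and the two lie within the scatter of each other.

On that basis the substitution at this position is expected to move this assay by no more than the scatter. The step this expectation means, a 1.2-fold lower number from compound 3 to compound 4 (0.09 log units; within the scatter), is expected to stay within the scatter. Compound 4 is therefore estimated at 2600 nM, with a range of 1200 nM to 5600 nM.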

Compound 4, half-maximal inhibitory concentration: 4120 nM
Compound 4: the middle estimate sits 1.6-fold (0.20 log units) below what was measured; low and high end bracket the measured number.
By their numbers in this assay, from the lowest: compounds 1, 2, 3 and 4 (each within the scatter of the next).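

In this assay, the change from 4-chlorophenyl to 4-(trifluoromethyl)phenyl now has a direct reading, a 1.3-fold higher number from compound 3 to compound 4 (0.11 log units; within the scatter), and the change from methoxy to trifluoromethyl at the same aromatic carbon gives a 1.6-fold higher number from compound 2 to compound 4 (0.20 log units; within the scatter), so methoxy, chloro and trifluoromethyl all lie within the scatter of each other at this position when the fluoro substituent is present. Among these compounds, the fluoro substituent can also be read on its own for the first time: fluoro in place of hydrogen on the trifluoromethyl compounds gives a 1.9-fold higher number from compound 1 to compound 4 (0.28 log units; within the scatter) and also stays within the scatter, so neither of the two places varied here has yet moved this cytotoxicity read-out measurably. Nothing at hand bears on what lies behind these small steps.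

As far as these compounds go, it remains open whether a group of another kind on the same aromatic carbon, such as an amine or a carboxylic acid, would move the number beyond the scatter. From the compounds shown here alone, the fluoro step rests on the trifluoromethyl pair alone, so its size with chloro or methoxy on the pendant ring also remains open.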